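The source may report more compounds than this note shows. Statements on the series, on what has been measured and on what is new or still open speak of the compounds shown alone.

- compound 1 `CNc1nc(-c2cc(OC)c(OC)c(OC)c2)c(-c2ccc(OC)cc2)s1`: 70.1 nM
- compound 2 `COc1cc(-c2nc(N(C)C)sc2-c2ccc3ccccc3c2)cc(OC)c1OC`: 1400 nM

In a functional assay on HeLa cells (Homo sapiens) for antiproliferative activity, read by MTT assay, with a stated time of 72 h (a higher number here means a weaker inhibitor, a lower number a stronger inhibitor), compound 2 at 1400 nM has the higher of the two numbers, beyond the scatter from compound 1 . Compound 3 `CCOc1ccc(-c2sc(N(C)C)nc2-c2cc(OC)c(OC)c(OC)c2)cc1` differs from compound 2 in one place: 4-ethoxyphenyl in place of naphthalen-2-yl on an aromatic carbon. Among the compounds with values here, no measured pair shows this change, so the expectation is loose. A lower number, beyond the scatter, is expected, resting only on compound 1 , which lacks naphthalen-2-yl and gives 70.1 nM. The expected change is a 4.7-fold lower number from compound 2 to compound 3 (0.67 log units; beyond the scatter). For compound 3 the estimate is 300 nM, with an expected range of 60 nM to 1500 nM.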

Compound 3, half-maximal inhibitory concentration: 3260 nM
Compound 3: the middle estimate sits 11-fold (1.04 log units) below what was measured, outside the stated range (above it).
By their numbers in this assay, from the lowest: compound 1; then compound 2; then compound 3.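

In this assay, the position on the aromatic carbon next to the ring sulfur now has a measured step: with the dimethylamino group kept, 4-ethoxyphenyl in place of naphthalen-2-yl gives a 2.3-fold higher number from compound 2 to compound 3 (0.37 log units; beyond the scatter). The change is modest, but it shows that the one-ring group does not improve on the two-ring group here. No measurement available here accounts for this shift.

As far as these compounds go, how 4-propoxyphenyl, with its longer chain, or 4-aminophenyl would fare at this position remains open. A single step cannot establish a trend.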